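The compounds below may be only part of what the source reports. "The series", "measured", "known", "first", "only" and "open" are said of these compounds alone.

Measured compounds:
compound 1, `CC(C)c1c(Cc2c(F)cccc2Cl)nc(SCC(=O)c2ccccc2)[nH]c1=O`: > 12000 nM
compound 2, `CC(C)c1c(Cc2c(F)cccc2Cl)nc(SCC(=O)c2ccc(F)cc2)[nH]c1=O`: > 56000 nM
compound 3, `Cc1c(Cc2c(F)cccc2F)nc(SCC(=O)c2ccccc2)[nH]c1=O`: 65000 nM

All three were tested in an ADME assay on MT4 cells (Homo sapiens) for cytotoxicity, read by MTT assay; a higher number here means that more compound is tolerated, a lower number that less compound is tolerated. For compound 1 the result is only a limit of the assay, (the limit of > 12000 nM in this assay, at which 1 of the 3 values shown sits). For compound 2 likewise the result is only a limit, (the limit of > 56000 nM in this assay, at which 1 of the 3 values shown sits). Compound 3 alone gives a number in this assay, 65000 nM.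

Compound 1 and compound 2 differ by fluoro in place of hydrogen on an aromatic carbon. The step that the two limits leave unreadable from compound 1 to compound 2 cannot be read, since both ends are limits. Compound 3 carries a different core from compound 1; the difference between the two cores is not broken down here.

The unmeasured compound 4, `Cc1c(Cc2c(F)cccc2F)nc(SCC(=O)c2ccc(F)cc2)[nH]c1=O`, differs from compound 3 by fluoro in place of hydrogen on an aromatic carbon, which is the same change as from compound 1 to compound 2, at a place described in the same words. Because the step that the two limits leave unreadable from compound 1 to compound 2 gives no readable size, the expectation for compound 4 rests mainly on compound 3 with 65000 nM, and the step of no change at the digits printed from compound 3 to compound 4 (within the scatter) is expected to stay small. Compound 4 is therefore estimated at 65000 nM in this assay, with a likely range from 30000 nM to 140000 nM.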

Compound 4, half-maximal cytotoxic concentration: > 62000 nM
Compound 4 gave a limit, no number; the forecaster's own chance of this, stated with the estimate: 40%; the middle value lies beyond the limit too.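

In this assay, compound 4 gives only a limit, > 62000 nM, and not a number. Among these compounds, the step between compound 3 and compound 4 therefore cannot be read, and no new step comes from this result. The compounds shown leave open how far, if at all, going from phenyl to 4-fluorophenyl shifts the concentration tolerated.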